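This account rests on a few compounds, and the source may have more. Where it says the series, first, only, none or still open, it means among the compounds named here.

Series notes on a shared amide core carrying a butanoyloxymethylthio arm, tested in an ADME assay on CEM-SS cells (Homo sapiens) for cytotoxicity, read by XTT assay, with a stated time of 6 days; a higher number here means that more compound is tolerated, a lower number that less compound is tolerated.

Three analogues have been measured. Compound 1 `CCCC(=O)OCSc1ccccc1C(=O)NCCCCC(N)=O` gives 51.7 uM. Compound 2 `CCCC(=O)OCSc1ccccc1C(=O)N[C@@H]1CCC[C@@H]1C(N)=O` gives 90 uM. Compound 3 `CCCC(=O)OCSc1ccccc1C(=O)N(C)CC(N)=O` gives 55.3 uM. On these numbers compound 1 carries the smallest value of the three, but neither gap separates it from the others: a 1.1-fold higher number from compound 1 to compound 3 (0.03 log units; within the scatter) and a 1.7-fold higher number from compound 1 to compound 2 (0.24 log units; within the scatter), so all three stand together within the scatter.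

Compound 4 `CCCC(=O)OCSc1ccccc1C(=O)NCC(=O)NCC(=O)OC` has not yet been measured. It differs from compound 1 in one place: ((methoxycarbonyl)methyl)carbamoyl in place of 3-carbamoylpropyl on a saturated chain carbon bound to an amide-type nitrogen. The change again reshapes the chain on the amide-type nitrogen, as the two measured steps from compound 1 did, and both of those stayed within the scatter. Within the data shown here, no measured step points in either direction, so no movement beyond the scatter is expected in this assay for compound 4; the expected step is a 1.2-fold higher number from compound 1 to compound 4 (0.06 log units; within the scatter). The estimate for compound 4 is 60 uM, with a range from 30 uM to 120 uM.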

Compound 4, half-maximal toxic concentration: > 100 uM
Compound 4 ended at the assay's limit (the forecaster's own chance of this, stated with the estimate: 10%); middle value at least 1.6-fold (0.22 log units) from the limit.
By their numbers in this assay, from the lowest: compounds 1, 3 and 2 (each within the scatter of the next). At a limit, above all of these: compound 4.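

In this assay compound 4 gives > 100 uM, which is a limit of the assay and not a number. The step reads an at least 1.9-fold higher number from compound 1 to compound 4 (0.28 log units; that floor lies within the scatter), so placing ((methoxycarbonyl)methyl)carbamoyl on a saturated chain carbon bound to an amide-type nitrogen yields only a floor, and that floor does not separate the change from the scatter. Unlike the three earlier compounds, which all have numerical values, compound 4 reaches the upper end of what the assay reads here, and the position therefore tolerates this longer, ester-bearing group without any sign of a lower number: the limit of > 100 uM in this assay, at which 1 of the 4 values shown sits.

On these data alone, how far compound 4 lies past the limit remains open. Also open, as far as these compounds go, is whether a carboxylic acid in place of the methoxycarbonyl group, or a longer chain carrying the same ester, gives a value at the limit.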